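This account rests on a few compounds, and the source may have more. Where it says the series, first, only, none or still open, it means among the compounds named here.

Compound 3 `COc1cc(-c2nn(-c3cccc(NC(=O)Nc4cccc(C(F)(F)F)c4)c3)cc2-c2ccncc2)ccc1Cl` stands among three compounds of which none gives a number in a functional assay on T47D cells (Homo sapiens) for inhibition, read by sulforhodamine B assay, with a stated time of 48 h; a lower number here means a stronger inhibitor of growth, a higher number a weaker inhibitor of growth. In this assay compound 3 gives only a limit, > 50000 nM. Compound 1 `O=C(Nc1cccc(-n2cc(-c3ccncc3)c(-c3ccc(Cl)c(O)c3)n2)c1)Nc1cccc(C(F)(F)F)c1` likewise gives only a limit, > 32500 nM. Compound 2 `COc1cc(-c2nn(-c3cccc(NC(=O)Nc4cc(C(F)(F)F)cc(C(F)(F)F)c4)c3)cc2-c2ccncc2)ccc1Cl` also gives only a limit, > 50000 nM. The two steps into compound 3, a step that the two limits leave unreadable from compound 1 to compound 3 and a step that the two limits leave unreadable from compound 2 to compound 3, cannot be read in size, since they rest on the limit of > 32500 nM in this assay, at which 1 of the 3 values shown sits, and (the limit of > 50000 nM in this assay, at which 2 of the 3 values shown sit). Compound 4 `COc1cc(-c2nn(-c3cccc(NC(=O)Nc4ccc(Cl)c(C(F)(F)F)c4)c3)cc2-c2ccncc2)ccc1Cl` differs from compound 3 by chloro in place of hydrogen on an aromatic carbon. With no readable step to draw on, no change beyond the scatter is expected, and compound 4 is expected to stay at the limit as well. The estimate for compound 4 is 50000 nM, with a range from 20000 nM to 120000 nM. The expected step is a number no higher from compound 3 to compound 4 (the limit leaves the size open).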

Compound 4, concentration for total growth inhibition: > 32500 nM
Compound 4 ended at the assay's limit; the forecaster's own chance of this, stated with the estimate: 80%; the middle value does not contradict the limit.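

Compound 3 and compound 4 both give only limits in this assay, so the size of the step between them cannot be read. The compounds shown leave open whether chloro in place of hydrogen changes growth inhibition at all.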